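The source may report more compounds than this note shows. Statements on the series, on what has been measured and on what is new or still open speak of the compounds shown alone.

Working notes on the series.

Going by the values given here, compound 2 `Cc1cc(Cl)cc(-c2ccnc3cc(CN4C(=O)CCC4=O)sc23)c1O[C@H]1CCCNC1` is the only member of the series with a number in an ADME assay on the whole organism (Rattus norvegicus, strain Sprague-Dawley) for pharmacokinetics, at a dose of 0.5 mg/kg by the intravenous route; a higher number here means faster removal of the compound, a lower number slower removal: compound 2 gives 81.7 mL/min/kg there. Compound 1 `Cc1cc(Cl)cc(-c2ccnc3cc(CN4C(=O)CCC4=O)sc23)c1O[C@H]1C[C@H](N)C1` was entered into this assay, and for compound 1 the entry reads "not determined" (no result reported), so no result was reported. The same holds for compound 3 `O=C1CCC(=O)N1Cc1cc2nccc(-c3cc(Cl)cc4c3O[C@@H](c3ocnc3CN3CCC3)C4)c2s1`: for compound 3 the entry reads "not determined" (no result reported), with no result reported in this assay. Among the compounds with values here, compound 2 therefore stands alone; it cannot be ranked against compound 1 or compound 3, and no step between measured compounds exists in this assay.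

Compound 4 `Cc1cc(Cl)cc(-c2ccnc3cc(CN4C(=O)CCC4=O)sc23)c1OC1CCNCC1` is not yet measured. It differs from compound 2 in one place: piperidin-4-yl in place of piperidin-3-yl on an oxygen on an aromatic ring. The two have the same atoms, joined differently; the group that leaves and the group that enters each carry one hydrogen-bond donor and one hydrogen-bond acceptor, with no net charge, and the only loss is the defined stereocentre of compound 2.

Within the data shown here, with no step between measured compounds available as a guide, the expected change for such a rearrangement is small, with no clear direction, and the estimated step from compound 2 to compound 4 in this assay is a 1.1-fold lower number from compound 2 to compound 4 (0.04 log units; within the scatter), which is within the usual scatter. Compound 4 is accordingly expected to show 75 mL/min/kg in this assay, within a range from 40 mL/min/kg to 140 mL/min/kg.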

Compound 4, clearance: 5.5 mL/min/kg
The estimate for compound 4 lay 14-fold (1.13 log units) above the measured number, and the stated range ends above it.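

In this assay, going by these compounds alone, the change of piperidin-3-yl to piperidin-4-yl on an oxygen on an aromatic ring gives a 15-fold lower number from compound 2 to compound 4 (1.17 log units; beyond the scatter) and is the first step that can be read. It shows that this position is far from indifferent to how the piperidine is joined: the same atoms, with the same counted hydrogen-bond donor and acceptor and no net charge, separate two compounds well beyond the scatter, so the read-out here responds to the attachment of the ring and not only to its composition. No measurement at hand bears on the origin of this step.

The single step also changes two things at once, the point of attachment and the loss of the defined stereocentre, and the compounds shown do not tell these apart, since the opposite stereoisomer of the piperidin-3-yl group does not appear among them. On these data alone, whether the low number belongs to piperidin-4-yl alone, or would carry over to a pyrrolidine ring, a morpholine or an open-chain amine on the same oxygen, also remains open.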